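The source may hold more compounds than are shown below. What is called first, only, known or untested is meant among the compounds shown, and "the series" means these compounds.

In an ADME assay on Vero cells (Chlorocebus sabaeus) for cytotoxicity, read by MTT assay, with a stated time of 72 h (on this read-out lower numbers stand for higher toxicity in this test and higher numbers for lower toxicity in this test), three compounds of a shared core have been measured. Compound 1 `COc1ccc(/C=C/C(=O)Nc2nnc(-c3ccccc3)[nH]2)cc1OC` gives 1210000 nM, compound 2 `O=C(/C=C/c1ccc(OC(F)(F)F)cc1)Nc1nnc(-c2ccccc2)[nH]1` gives 1560000 nM, and compound 3 `O=C(/C=C/c1cccc([N+](=O)[O-])c1)Nc1nnc(-c2ccccc2)[nH]1` gives 1990000 nM. Compound 2 sits among them with the two others on either side, both within the usual scatter, so the three numbers read as one level. Compound 4 `C=C(C)COc1ccc(/C=C/C(=O)Nc2nnc(-c3ccccc3)[nH]2)cc1` differs from compound 2 by 2-methylprop-2-en-1-yl in place of trifluoromethyl on an oxygen on an aromatic ring. Within the data shown here, no measured pair shows this change, and the three measured compounds give no sign that the substituent on this oxygen moves the read-out. Compound 4 is therefore expected to stay near the shared level, with a step from compound 2 to compound 4 in this assay estimated at a 1.0-fold lower number from compound 2 to compound 4 (0.02 log units; within the scatter), not beyond the scatter. For compound 4 the estimated value is 1500000 nM, with a range from 600000 nM to 3500000 nM.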

Compound 4, half-maximal cytotoxic concentration: 1420000 nM
The estimate for compound 4 lay 1.1-fold (0.02 log units) above the measured number; the range from low to high includes it.
By their numbers in this assay, from the lowest: compounds 1, 4, 2 and 3 (each within the scatter of the next).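

In this assay the oxygen on an aromatic ring now has a direct pair, where 2-methylprop-2-en-1-yl in place of trifluoromethyl gives a 1.1-fold lower number from compound 2 to compound 4 (0.04 log units; within the scatter) and so stays within the scatter. Among these compounds, this is the first sign from a single change that this position tolerates replacing the fluorine-bearing group with an all-carbon group holding a double bond without moving the read-out. Nothing available explains this result.

From the compounds shown here alone, whether an amine or a carboxylic acid on this oxygen would keep the read-out at the same level remains open. So does whether a longer chain would.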